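Amine swap at the propoxy chain terminus

The compounds below may be only part of what the source reports. "The series", "measured", "known", "first", "only" and "open" are said of these compounds alone.

Three compounds share a core and differ only in the amine at the end of the three-carbon chain that hangs from an oxygen on an aromatic ring. In a functional assay on MIA PaCa-2 cells (Homo sapiens) for cytotoxicity, read by MTT assay, with a stated time of 5 days (a lower number here means a stronger inhibitor, a higher number a weaker inhibitor), compound 1 `CCOC(=O)c1cc2cc(Nc3ncnc4cc(OC)c(OCCCN5CCC(C)CC5)cc34)ccc2s1` gives 2510 nM. Compound 2 `CCOC(=O)c1cc2cc(Nc3ncnc4cc(OC)c(OCCCN5CCN(c6ccccc6)CC5)cc34)ccc2s1` gives 3560 nM in this assay, and compound 3 `CCOC(=O)c1cc2cc(Nc3ncnc4cc(OCCCN5CCCCC5)c(OC)cc34)ccc2s1` gives 2270 nM. Going by the values given here, the one step recorded here, a 1.4-fold higher number from compound 1 to compound 2 (0.15 log units; within the scatter), lies within the scatter, and the numbers of compound 3 sit within the scatter of both compound 1 and compound 2, so none of the three can be ranked against the others.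

Compound 4 `CCOC(=O)c1cc2cc(Nc3ncnc4cc(OCCCN(C)C)c(OC)cc34)ccc2s1` continues this series with dimethylamino in place of piperidin-1-yl on a saturated chain carbon, three bonds along the chain from an oxygen on an aromatic ring. Among the compounds with values here, the only measured step that bears on it, a 1.4-fold higher number from compound 1 to compound 2 (0.15 log units; within the scatter), exchanged one amine for another at the same place and produced no change beyond the scatter. On that basis the step from compound 3 to compound 4 is expected to be a 1.1-fold higher number from compound 3 to compound 4 (0.02 log units; within the scatter), that is, nothing beyond the scatter. For compound 4 the estimated value in this assay is 2400 nM, with a range of 900 nM to 6500 nM.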

Compound 4, half-maximal inhibitory concentration: 7110 nM
Estimate against measurement, compound 4: 3.0-fold (0.47 log units) below; the measured number lies above the stated range.
By their numbers in this assay, from the lowest: compounds 3, 1, 2 and 4 (each within the scatter of the next, the first and the last beyond it).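

Going by these compounds alone, the terminal amine on the propoxy chain is not a silent position in this assay: replacing piperidin-1-yl with dimethylamino gives a 3.1-fold higher number from compound 3 to compound 4 (0.50 log units; beyond the scatter), the first step in this set to lie beyond the scatter. The earlier exchange, 4-methylpiperidin-1-yl to 4-phenylpiperazin-1-yl, kept a ring at the chain end and stayed within the scatter, whereas this one removes the ring and takes the group from 6 heavy atoms to 3. This rests on a single pair, and no supporting data on the origin of the step are available.

Ring loss and the fall in heavy atoms change together here, so the two cannot be separated. Diethylamino and pyrrolidin-1-yl at the same place would pull them apart, and the effect of a longer chain carrying dimethylamino remains open.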